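Cyclopentyl in Place of Ethyl on the Ketone Chain

The source may hold more compounds than are shown below. What is called first, only, known or untested is meant among the compounds shown, and "the series" means these compounds.

Of the compounds shown here, three with a shared core have been measured in an assay on HEK293 cells for positive allosteric modulation of metabotropic glutamate receptor 2 (Rattus norvegicus), read by thallium flux, with a stated time of 2.5 min; on this read-out higher numbers stand for an effect only at larger amounts of compound and lower numbers for an effect already at smaller amounts. Compound 1 `Cc1c(OCCCCOc2ccc(C(=O)O)cc2)ccc(C(=O)CC2CCCC2)c1O` gives 824 nM, compound 2 `Cc1c(OCCCCOCOc2ccc(C(=O)O)cc2)ccc(C(=O)CC2CCCC2)c1O` gives 228 nM, and compound 3 `CCCC(=O)c1ccc(OCCCCOc2cc(C(=O)O)ccc2OC)c(C)c1O` gives 103 nM. For the measured compounds named here, the only step between two compounds that differ in one place is a 3.6-fold lower number from compound 1 to compound 2 (0.56 log units; beyond the scatter), and it concerns the linker between the two aromatic parts. Compound 3 stands lowest of the three numbers, with its steps to compound 2 and to compound 1 both beyond the scatter, so it is the most potent of the measured set.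

Compound 4 `COc1ccc(C(=O)O)cc1OCCCCOc1ccc(C(=O)CC2CCCC2)c(O)c1C` differs from compound 3 by cyclopentyl in place of ethyl on a saturated chain carbon bound to a carbonyl carbon. Going by the values given here, no measured step bears directly on this change: the step of a 3.6-fold lower number from compound 1 to compound 2 (0.56 log units; beyond the scatter) touches a different part of the molecule. Compounds 1 and 2 already carry the cyclopentylmethyl ketone, but they differ from compound 4 in further places as well, so their values show only what those two compounds give and not what the ketone chain alone does. Among the compounds with values here, with no bearing step, no change beyond the scatter is expected. Compound 4 is therefore estimated at 110 nM, with a range from 35 nM to 350 nM. This estimate corresponds to a 1.1-fold higher number from compound 3 to compound 4 (0.03 log units; within the scatter).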

Compound 4, half-maximal effective concentration: 425 nM
Compound 4: middle estimate off by 3.9-fold (0.59 log units), on the low side; the measured number lies above the stated range.
By their numbers in this assay, from the lowest: compound 3; then compounds 2, 4 and 1 (each within the scatter of the next, the first and the last beyond it).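

In this assay, the ketone chain turns out to be a place that responds: cyclopentyl in place of ethyl on a saturated chain carbon bound to a carbonyl carbon gives a 4.1-fold higher number from compound 3 to compound 4 (0.62 log units; beyond the scatter), the first step read at this position and the only new one beyond the scatter. With the cyclopentylmethyl ketone held fixed, the changes at the acid-bearing end stay within the scatter: 5-carboxy-2-methoxyphenyl in place of 4-carboxyphenyl gives a 1.9-fold lower number from compound 1 to compound 4 (0.29 log units; within the scatter), and the same group in place of (4-carboxyphenoxy)methyl gives a 1.9-fold higher number from compound 2 to compound 4 (0.27 log units; within the scatter). Nothing available explains why the change on the ketone chain moves the number.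

The compounds shown leave open whether a cyclobutyl, a cyclohexyl or an open branched chain such as isopropyl on the same carbon would fall nearer compound 3 or compound 4. They also leave open whether ethyl in place of cyclopentyl would give a step of similar size with the 4-carboxyphenyl group of compound 1, since that partner is not among them.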